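The source may hold more compounds than are shown below. What is called first, only, known or untested is meant among the compounds shown, and "the series" means these compounds.

Within the data shown here, the three compounds measured so far share one core and differ only in the ring attached to the carbonyl carbon. Compound 1 `O=C(Nc1ccc(OC(F)(F)F)cc1)NC1CCN(C(=O)c2ccoc2)CC1` gives 26 ug/mL in a physicochemical assay for solubility, read by mass spectrometry, in phosphate buffer, with a stated time of 24 h, at pH 3; on this read-out lower numbers stand for lower solubility and higher numbers for higher solubility. Compound 2 `Cc1occc1C(=O)N1CCC(NC(=O)Nc2ccc(OC(F)(F)F)cc2)CC1` gives 7.7 ug/mL in this assay, and compound 3 `Cc1ccoc1C(=O)N1CCC(NC(=O)Nc2ccc(OC(F)(F)F)cc2)CC1` gives 3.4 ug/mL in this assay. Compound 3 therefore stands lowest of the three numbers, with a 2.3-fold lower number from compound 2 to compound 3 (0.36 log units; beyond the scatter) and a 7.6-fold lower number from compound 1 to compound 3 (0.88 log units; beyond the scatter).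

The next compound, compound 4 `O=C(Nc1ccc(OC(F)(F)F)cc1)NC1CCN(C(=O)C2CCOC2)CC1`, is made from compound 3 by one change: oxolan-3-yl in place of 3-methylfuran-2-yl on a carbonyl carbon. Among the measured compounds shown here, none of the measured steps exchanges an aromatic ring for a non-aromatic one, so they bear on this change only in part. The step of a 3.4-fold lower number from compound 1 to compound 2 (0.53 log units; beyond the scatter) shows that adding a methyl on an aromatic carbon lowered the number, and the change to compound 4 removes that methyl together with the aromatic ring that carried it. On this basis a rise is expected, though its size is uncertain and the estimated step is a 12-fold higher number from compound 3 to compound 4 (1.07 log units; beyond the scatter). Compound 4 is therefore expected to give 40 ug/mL in this assay, with a range from 12 ug/mL to 130 ug/mL.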

Compound 4, solubility: 91 ug/mL
Beside the measured number, compound 4's estimate is 2.3-fold (0.36 log units) below it, within the range that was stated.
By their numbers in this assay, from the lowest: compound 3; then compound 2; then compound 1; then compound 4.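

In this assay, among these compounds, the change at this carbonyl carbon now goes from an aromatic ring to a non-aromatic one for the first time, and oxolan-3-yl gives the highest number of the four compounds, with a 27-fold higher number from compound 3 to compound 4 (1.43 log units; beyond the scatter) and a 12-fold higher number from compound 2 to compound 4 (1.07 log units; beyond the scatter) as the two large steps from the methylfuran rings. The remaining comparison has no methyl on either side, and a 3.5-fold higher number from compound 1 to compound 4 (0.54 log units; beyond the scatter) shows that the number still rises when furan-3-yl becomes oxolan-3-yl, so losing a methyl is not needed for a rise at this position, although this step is smaller than the two that start from a methylfuran ring. Nothing available here accounts for these rises.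

The compounds shown leave open what a methyl on the oxolan-3-yl ring would do to the number, and what an amine or a carboxylic acid on that ring would give. Whether the order of these four compounds holds at another pH also remains an open question.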